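The source may report more compounds than this note shows. Statements on the series, on what has been measured and on what is new or still open speak of the compounds shown alone.

Of the compounds shown here, three built on one shared core have been measured in an assay on NIH3T3 cells with Urotensin-2 receptor (Homo sapiens) as the target; a higher number here means that more compound is needed for the effect, a lower number that less compound is needed. Compound 1 `COc1ccc(NC(=O)NC(CCN(C)C)c2ccc(Cl)cc2)cc1` gives 2000 nM. Compound 2 `CN(C)CCC(NC(=O)Nc1ccc(C(F)(F)F)cc1)c1ccc(Cl)cc1` gives 117 nM, and compound 3 `CN(C)CCC(NC(=O)Nc1ccc(-c2ccccc2)cc1)c1ccc(Cl)cc1` gives 145 nM. Among these three numbers compound 3 stands second highest; its nearest neighbour is compound 2, and the step of a 1.2-fold higher number from compound 2 to compound 3 (0.09 log units; within the scatter) lies within the scatter, so the two cannot be told apart. The step of a 14-fold lower number from compound 1 to compound 3 (1.14 log units; beyond the scatter) is large, as is the step of a 17-fold lower number from compound 1 to compound 2 (1.23 log units; beyond the scatter).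

Compound 4 `CN(C)CCC(NC(=O)Nc1ccc(Oc2ccccc2)cc1)c1ccc(Cl)cc1` has not yet been measured. It differs from compound 3 in one place: phenoxy in place of phenyl on an aromatic carbon. Among the measured compounds shown here, no measured step swaps phenyl for phenoxy, so the expectation rests on indirect ground. For the measured compounds named here, the only oxygen-linked group among the measured compounds, methoxy in compound 1, gave the highest number, while phenyl and trifluoromethyl gave the lower numbers; a phenoxy group, however, keeps the aromatic ring that compound 3 carries. The step expected in this assay is therefore modest: a 1.4-fold higher number from compound 3 to compound 4 (0.14 log units; within the scatter). Compound 4 is estimated at 200 nM, with a likely range from 60 nM to 700 nM.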

Compound 4, half-maximal effective concentration: 110 nM
Beside the measured number, compound 4's estimate is 1.8-fold (0.26 log units) above it, within the range that was stated.
By their numbers in this assay, from the lowest: compounds 4, 2 and 3 (each within the scatter of the next); then compound 1.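

In this assay, an oxygen on this aromatic carbon turns out to be compatible with a low number: keeping that oxygen and putting phenyl in place of its methyl gives an 18-fold lower number from compound 1 to compound 4 (1.26 log units; beyond the scatter), a large step. Phenoxy in place of phenyl gives a 1.3-fold lower number from compound 3 to compound 4 (0.12 log units; within the scatter), and phenoxy in place of trifluoromethyl gives a 1.1-fold lower number from compound 2 to compound 4 (0.03 log units; within the scatter), so compound 2, compound 3 and compound 4 cannot be told apart, and among these four compounds only compound 1, with its methoxy group, stands apart. Nothing shown here explains why the methoxy compound differs from the other three.

On these data alone, it remains open how the number changes as the group on that oxygen grows from the methyl of compound 1 to the phenyl of compound 4, which an ethyl group, a longer chain or a benzyl group on the same oxygen could help to show. As far as these compounds go, it is also open whether quite different groups on this aromatic carbon, such as an amine or a carboxylic acid, would match compound 2, compound 3 and compound 4 or fall nearer to compound 1.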